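Moving a methyl around the piperidine ring

The source may report more compounds than this note shows. Statements on the series, on what has been measured and on what is new or still open speak of the compounds shown alone.

In a functional assay on U-937 cells (Homo sapiens) for cytotoxicity, read by WST assay, with a stated time of 72 h (on this read-out higher numbers stand for weaker inhibition and lower numbers for stronger inhibition), the three measured compounds gave these numbers:
compound 1 `COc1cc2c(Nc3nc4ccc(C(=O)Nc5c(C)cc(C)cc5C)cc4s3)ncnc2cc1OCCCN1CCC(C)CC1`: 5600 nM
compound 2 `COc1cc2c(Nc3nc4ccc(C(=O)Nc5c(C)cccc5C)cc4s3)ncnc2cc1OCCCN1CCCCC1`: 14700 nM
compound 3 `COc1cc2c(Nc3nc4ccc(C(=O)Nc5c(C)cccc5C)cc4s3)ncnc2cc1OCCCN1CCCCC1C`: 10800 nM

Compound 3 stands second highest of the three numbers. Its nearest neighbour is compound 2, and that gap lies within the scatter; compound 1 is furthest from it, yet that gap too lies within the scatter, so no order among the three can be read from these numbers. Compound 4 `COc1cc2c(Nc3nc4ccc(C(=O)Nc5c(C)cccc5C)cc4s3)ncnc2cc1OCCCN1CCC(C)CC1` differs from compound 3 by 4-methylpiperidin-1-yl in place of 2-methylpiperidin-1-yl on a saturated chain carbon, three bonds along the chain from an oxygen on an aromatic ring. Going by the values given here, only one measured step touches this ring: a 1.4-fold lower number from compound 2 to compound 3 (0.13 log units; within the scatter), which is within the scatter. Among the compounds with values here, compound 1 also carries the 4-methylpiperidin-1-yl group, but it differs from compound 4 in a second place, so its number gives no step that bears directly on the change. Nothing here shows that the position of the methyl on the ring shifts this read-out beyond the scatter, and compound 4 is therefore expected to sit close to compound 3. The expected step is a 1.2-fold lower number from compound 3 to compound 4 (0.08 log units; within the scatter). For compound 4 the estimate in this assay is 9000 nM, with a range from 4500 nM to 18000 nM.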

Compound 4, half-maximal inhibitory concentration: 11200 nM
For compound 4 the middle estimate is 1.2-fold (0.09 log units) below the measured one, within the range that was stated.
By their numbers in this assay, from the lowest: compounds 1, 3, 4 and 2 (each within the scatter of the next, the first and the last beyond it).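

In this assay, going by these compounds alone, the exchange of 2-methylpiperidin-1-yl for 4-methylpiperidin-1-yl now has a direct measure of a 1.0-fold higher number from compound 3 to compound 4 (0.02 log units; within the scatter) and so shows what the earlier compounds could not: on this ring, moving the methyl does not shift the read-out beyond the scatter. Methyl in place of hydrogen on a saturated ring carbon now has a second instance in a 1.3-fold lower number from compound 2 to compound 4 (0.12 log units; within the scatter) and, like a 1.4-fold lower number from compound 2 to compound 3 (0.13 log units; within the scatter) before it, stays within the scatter whichever of the two ring positions carries the methyl. Compound 1 also gains its first partner that differs in one place, and a 2.0-fold higher number from compound 1 to compound 4 (0.30 log units; within the scatter) puts hydrogen in place of methyl on an aromatic carbon within the scatter as well, though only just.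

The available evidence offers no account of why these numbers stay so close. The compounds shown also leave open whether a morpholine, a dimethylamine or a carboxylic acid in place of the methylpiperidine, or a longer chain than the propyl linker, would take the number in this assay beyond the scatter.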